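A 4-chloro-1H-pyrazol-1-yl group replaces a fused bicyclic group

The source may report more compounds than this note shows. Statements on the series, on what has been measured and on what is new or still open speak of the compounds shown alone.

In a physicochemical assay for lipophilicity, using the shake flask method, at pH 7.4 (a higher number here means a more lipophilic compound, a lower number a more polar compound), compound 1 `O=C(O)CCNC(=O)c1ccc(C(Oc2ccc(-n3cc(C(F)(F)F)cn3)cc2)C2CCC2)cc1` gives 2.6 and compound 2 `CCCC(Oc1ccc(-n2cc(C(F)(F)F)c(C)n2)cc1)c1ccc(C(=O)NCCC(=O)O)cc1` gives 2.8 while compound 3 `CCCC(Oc1ccc(-n2cc3c(n2)CCCC3)cc1)c1ccc(C(=O)NCCC(=O)O)cc1` gives 2.7 on the same scale. Compound 3 therefore stands within the scatter of both other compounds. Compound 4 `CCCC(Oc1ccc(-n2cc(Cl)cn2)cc1)c1ccc(C(=O)NCCC(=O)O)cc1` differs from compound 3 by a group of 6 heavy atoms (3 carbon, 2 nitrogen, 1 chlorine; one five-membered aromatic ring with 2 hetero atoms) in place of a group of 9 heavy atoms (7 carbon, 2 nitrogen; one five-membered aromatic ring with 2 hetero atoms, one six-membered non-aromatic ring of carbon only), on an aromatic carbon and keeps the rest of the structure. Within the data shown here, the one measured step that exchanges a group at that place is a number 0.10 log units lower from compound 2 to compound 3 (within the scatter) and it offers the only direct guide. Among the measured compounds shown here, no compound measured so far carries the 4-chloro-1H-pyrazol-1-yl group. A move beyond the scatter is not expected, and the estimated step is a number 0.20 log units lower from compound 3 to compound 4 (within the scatter) in this account. For compound 4 the expected value is 2.5 with a range from 2.2 to 2.8 in this estimate.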

Compound 4, distribution coefficient: 2.6
The estimate for compound 4 lay 0.10 log units below the measured number; measured number inside the range.
By their numbers in this assay, from the lowest: compounds 1, 4, 3 and 2 (each within the scatter of the next).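

In this assay, the 4-chloro-1H-pyrazol-1-yl group on this aromatic carbon gives a number 0.10 log units lower from compound 3 to compound 4 (within the scatter) and a number 0.20 log units lower from compound 2 to compound 4 (within the scatter). The position thus holds three different groups in compounds 2, 3 and 4 with no step beyond the scatter, even where the entering group has 6 heavy atoms in place of 9. No evidence is available on what lies behind these numbers. The compounds shown leave open whether an amine or a carboxylic acid on the pyrazole in place of the chlorine would also stay within the scatter.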